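Working notes: replacing the naphthalen-2-yl group of compound 2

This account rests on a few compounds, and the source may have more. Where it says the series, first, only, none or still open, it means among the compounds named here.

Measured so far:
compound 1, `COc1ccc([C@@H]2[C@@H](Oc3ccccc3)C(=O)N2c2cc(OC)c(OC)c(OC)c2)cc1`: 6900 nM
compound 2, `COc1cc(N2C(=O)[C@@H](Oc3ccccc3)[C@H]2c2ccc3ccccc3c2)cc(OC)c1OC`: 282000 nM
compound 3, `COc1ccc([C@@H]2[C@@H](Oc3ccccc3)C(=O)N2c2cc(OC)c(OC)c(OC)c2)cc1[N+](=O)[O-]`: 4100 nM

In a functional assay on MCF7 cells (Homo sapiens) for antiproliferative activity, read by MTT assay, with stated times of 24 h and 72 h (a lower number here means a stronger inhibitor, a higher number a weaker inhibitor), compound 2 stands highest of the three numbers; compound 1 is the nearest, with a number lower by a margin beyond the scatter, and compound 3 the furthest, again beyond the scatter. Compound 4, `COc1cc(N2C(=O)[C@@H](Oc3ccccc3)[C@H]2c2ccc(O)cc2)cc(OC)c1OC`, is derived from compound 2 by one change: 4-hydroxyphenyl in place of naphthalen-2-yl on a saturated ring carbon.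

Going by the values given here, only one step is measured in this assay, a 1.7-fold lower number from compound 1 to compound 3 (0.23 log units; within the scatter), which concerns an aromatic carbon on a different part of the molecule and does not bear directly on the present change. Among the compounds with values here, no measured step removes the naphthalen-2-yl group. What can be said is that compound 1, which carries a different group on the same saturated ring carbon, gives 6900 nM, whereas compound 2 gives 282000 nM; the two numbers lie far apart. Compound 4 carries a single six-membered aromatic ring at that carbon, as compound 1 does, so a large step downward from compound 2 is expected, into the region occupied by compound 1 and compound 3, although the exact size is uncertain.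

Compound 4 is therefore estimated at 10000 nM, with a range of 2500 nM to 45000 nM. This estimate means an expected step of a 28-fold lower number from compound 2 to compound 4 (1.45 log units; beyond the scatter).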

Compound 4, half-maximal inhibitory concentration: 48000 nM
Estimate against measurement, compound 4: 4.8-fold (0.68 log units) below, and the stated range ends below it.
By their numbers in this assay, from the lowest: compounds 3 and 1 (each within the scatter of the next); then compound 4; then compound 2.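

In this assay the change at this saturated ring carbon can now be read directly as a 5.9-fold lower number from compound 2 to compound 4 (0.77 log units; beyond the scatter) and shows that this position responds to the group it carries, even though the shared core and the phenoxy group stay the same. The step leaves compound 4 at 48000 nM and still apart from compound 1 at 6900 nM in the same assay, so a single six-membered aromatic ring at this carbon does not by itself bring the number down to that of compound 1, and what that ring carries also counts. No measurement offered here accounts for either difference.

The step from compound 2 to compound 4 removes one aromatic ring and adds a hydroxyl group in a single change, so the share of each remains unresolved, and an unsubstituted phenyl group at this carbon would separate the two. Also open, from the compounds shown here alone, is how the ring would behave with an amine or a carboxylic acid in place of the hydroxyl group of compound 4.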